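This account rests on a few compounds, and the source may have more. Where it says the series, first, only, none or still open, it means among the compounds named here.

The compounds here share one core, and growth inhibition is the only measure available. In a functional assay on HT-29 cells (Homo sapiens) for inhibition, read by sulforhodamine B assay, with a stated time of 48 h (a lower number here means a stronger inhibitor of growth, a higher number a weaker inhibitor of growth), compound 2 `CC(C)(C)NCc1c(C(=O)O)nn(-c2ccccc2)c1-c1ccc(F)cc1` gives no number, only a limit of > 680000 nM. Compound 3 `COc1ccc(-c2c(CNC(C)(C)C)c(C(=O)O)nn2-c2ccccc2)cc1` also gives only a limit, > 659000 nM. Compound 1 `CCOC(=O)c1nn(-c2ccc(Cl)cc2)c(-c2ccc(F)cc2)c1CNC(C)(C)C` gives 87100 nM; > 537000 nM (2 entries) across its several entries. Compound 2 therefore has no measured strength of its own and stands only as a very weak inhibitor of growth.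

Compound 4 `CC(C)(C)NCc1c(C(=O)O)nn(-c2ccc(Cl)cc2)c1-c1ccc(F)cc1` arises from compound 2 by a single change, chloro in place of hydrogen on an aromatic carbon, turning a phenyl into a 4-chlorophenyl. Among the compounds with values here, the one measured step nearby, a step that the two limits leave unreadable from compound 2 to compound 3, swaps methoxy for fluoro, so it offers no size to carry over. Compound 1 does carry the same 4-chlorophenyl as compound 4, but it is an ethyl ester where compound 4 is an acid, so its entries cannot show what chloro alone does.

With so little to go on, no clear move in either direction is expected, and another limit is the likeliest outcome. The estimated step is an at least 1.0-fold lower number from compound 2 to compound 4 (0.04 log units; that floor lies within the scatter). For compound 4 the expected value is 620000 nM, with an estimated range from 250000 nM to 750000 nM.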

Compound 4, concentration for 50% growth inhibition: > 623000 nM
Compound 4: only a limit was reported; the forecaster's own chance of this, stated with the estimate: 85%; at least 1.0-fold (0.00 log units) between middle value and limit.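

In this assay compound 4 gives > 623000 nM, which is a limit and not a number. Compound 2 also has only a limit, so no step can be read from compound 2 to compound 4. The compounds shown leave open what chloro in place of hydrogen does to growth inhibition on this core.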